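From 3-Nitrophenyl to 4-Nitrophenyl: Compound 4 Awaited

This account rests on a few compounds, and the source may have more. Where it says the series, first, only, none or still open, it means among the compounds named here.

Measured so far in a functional assay on PC-3 cells (Homo sapiens) for antiproliferative activity, read by MTT assay, with a stated time of 72 h (a higher number here means a weaker inhibitor, a lower number a stronger inhibitor), are three compounds
Compound 1 `O=C(N/N=C/c1ccc(Br)cc1)Nc1ccc(Oc2ccnc3[nH]ccc23)c(F)c1` gives 920 nM
Compound 2 `N#Cc1ccc(/C=N/NC(=O)Nc2ccc(Oc3ccnc4[nH]ccc34)c(F)c2)cc1` gives 9030 nM
Compound 3 `O=C(N/N=C/c1cccc([N+](=O)[O-])c1)Nc1ccc(Oc2ccnc3[nH]ccc23)c(F)c1` gives 5140 nM

Compound 3 stands close to one neighbour and apart from the other. The step of a 1.8-fold lower number from compound 2 to compound 3 (0.24 log units; within the scatter) lies within the scatter, whereas the step of a 5.6-fold higher number from compound 1 to compound 3 (0.75 log units; beyond the scatter) lies beyond it.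

Compound 4 `O=C(N/N=C/c1ccc([N+](=O)[O-])cc1)Nc1ccc(Oc2ccnc3[nH]ccc23)c(F)c1` has not yet been measured. It differs from compound 3 in one place (4-nitrophenyl in place of 3-nitrophenyl on a carbon with a double bond to nitrogen), with 4-nitrophenyl in place of 3-nitrophenyl on a carbon with a double bond to nitrogen.

For the measured compounds named here, no measured pair shows this exact exchange, so the evidence is indirect. The step of a 9.8-fold higher number from compound 1 to compound 2 (0.99 log units; beyond the scatter) shows that two compounds with a group at the same place can still differ modestly. The closest guide is the step of a 1.8-fold lower number from compound 2 to compound 3 (0.24 log units; within the scatter) that brings in 3-nitrophenyl for 4-cyanophenyl without a change beyond the scatter. The step of a 5.6-fold higher number from compound 1 to compound 3 (0.75 log units; beyond the scatter) is a reminder that a larger move remains possible, so the range is kept wide.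

The estimated change is a 1.1-fold lower number from compound 3 to compound 4 (0.06 log units; within the scatter) and no step beyond the scatter is expected in this assay here.

For compound 4 the estimated value is 4500 nM with an expected range from 1500 nM to 12000 nM as its limits.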

Compound 4, half-maximal inhibitory concentration: 150 nM
Estimate against measurement, compound 4: 30-fold (1.48 log units) above, and the stated range ends above it.
By their numbers in this assay, from the lowest: compound 4; then compound 1; then compounds 3 and 2 (each within the scatter of the next).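

In this assay, for the compounds shown here, moving the nitro group from 3-nitrophenyl to 4-nitrophenyl, with the atoms on both sides unchanged, gives a 34-fold lower number from compound 3 to compound 4 (1.53 log units; beyond the scatter) and so shows that the placing of this one group on the ring can matter greatly at this carbon, something no earlier pair could show since each of them also exchanged the group itself. With the group held in the same place, nitro for cyano gives a 60-fold lower number from compound 2 to compound 4 (1.78 log units; beyond the scatter) and nitro for bromo gives a 6.1-fold lower number from compound 1 to compound 4 (0.79 log units; beyond the scatter), so these three groups in that place are clearly separated and the nitro compound, compound 4, is the strongest inhibitor of those shown. The small step of a 1.8-fold lower number from compound 2 to compound 3 (0.24 log units; within the scatter) therefore did not mean that nitro and cyano can stand in for each other, since it compared groups in different places.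

The data offer no measurement that explains the effect of moving the nitro group. Going by these compounds, it remains open whether the gap between the two placings also holds for bromo or cyano, and how an amine or a carboxylic acid on the same ring would compare.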